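The source may report more compounds than this note shows. Statements on the series, on what has been measured and on what is new or still open speak of the compounds shown alone.

Three compounds built on one shared core were tested in a functional assay on THP-1 cells (Homo sapiens) for inhibition, read by sulforhodamine B assay, with a stated time of 48 h, tested at 50 uM; on this read-out lower numbers stand for less inhibition of growth and higher numbers for more inhibition of growth at the one concentration tested. Compound 1 `O=C1C(=O)N(CCCCn2cc(COc3cc(=O)oc4ccccc34)nn2)c2ccc([N+](=O)[O-])cc21` gives 55%. Compound 2 `COc1ccc2c(c1)C(=O)C(=O)N2CCCCn1cc(COc2cc(=O)oc3ccccc23)nn1` gives 52%. Compound 1 differs from compound 2 by nitro in place of methoxy on an aromatic carbon, and that change made a step of a number 3 percentage points higher from compound 2 to compound 1 (within the scatter), so these two compounds stand together. Compound 3 `COc1ccc2c(c1)C(=O)C(=O)N2CCCCCn1cc(COc2cc(=O)oc3ccccc23)nn1` gives 30%, the lowest of the three, well apart from both others; how its core differs from the core of compound 2 is not broken down here.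

Compound 4 `O=C1C(=O)N(CCCCCn2cc(COc3cc(=O)oc4ccccc34)nn2)c2ccc([N+](=O)[O-])cc21` has not yet been measured in this assay. It differs from compound 3 by nitro in place of methoxy on an aromatic carbon, the same change, at the same place, that already turned compound 2 into compound 1. Since that earlier step stayed within the scatter, compound 4 is expected to stay near compound 3, with a step of a number 3 percentage points higher from compound 3 to compound 4 (within the scatter). This expectation rests on the small step of a number 3 percentage points higher from compound 2 to compound 1 (within the scatter). Compound 4 is therefore estimated to give 33%, with a range from 20% to 46%.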

Compound 4, percent growth inhibition at one concentration: 37%
Estimate against measurement, compound 4: 4 percentage points below, and the stated range covers the measured number.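

In this assay, nitro in place of methoxy on an aromatic carbon gave a step of a number 7 percentage points higher from compound 3 to compound 4 (within the scatter), so the swap again left the number where it was, within what repeat measurements would be expected to show. Set beside the earlier case, the change looks the same on both cores: the same change on two cores in this assay, a number 3 percentage points higher (within the scatter) from compound 2 to compound 1 and a number 7 percentage points higher (within the scatter) from compound 3 to compound 4, 4 percentage points apart, within the scatter of two such steps This shows that, on these two cores, the swap carries over as a change too small to read; it does not show that nitro truly improves growth inhibition, that the same would hold on any other core, or how the compounds would compare at other concentrations, since each was tested at only one.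

The compounds shown leave open whether another group on that aromatic carbon, such as an amine or a carboxylic acid, would produce a step beyond the scatter. They also leave open how a longer chain would behave, and whether the swap would still make so little difference there.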